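Lengthening the Chain Toward an Octyl Analogue

A few compounds are considered here, and "the series" means these few. Any claim that something is new, unique, unknown or untested is made for them only; others in the source may bear on it.

Measured so far:
Compound 1, `CCCCCCCCCc1cc2cn(COCCO)c(=O)nc2o1`: >= 16000 nM
Compound 2, `CCCCCCc1cc2cn(COCCO)c(=O)nc2o1`: >= 400000 nM

In a functional assay on HEL cells (Homo sapiens), read by microscopy (a higher number here means that more compound is tolerated, a lower number that less compound is tolerated), compound 1 gives >= 16000 nM, which is a limit of the assay rather than a number. Compound 2 gives >= 400000 nM, also a limit. The step that the two limits leave unreadable from compound 1 to compound 2 therefore cannot be sized because the limit of >= 16000 nM in this assay, at which 1 of the 2 values shown sits, and the limit of >= 400000 nM in this assay, at which 1 of the 2 values shown sits, are both limits, so nothing about the direction or size of the change along the chain can be read from these two compounds.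

Compound 3, `CCCCCCCCc1cc2cn(COCCO)c(=O)nc2o1`, differs from compound 2 by ethyl in place of hydrogen on a saturated chain carbon, six bonds along the chain from an aromatic carbon. With no readable step to lean on, no change beyond the scatter can be predicted in either direction. Compound 3 is expected to give about 60000 nM, within 16000 nM to 400000 nM, and most likely again only as a limit. The step of an at least 6.6-fold lower number from compound 2 to compound 3 (0.82 log units; beyond the scatter) is thus an estimate with wide uncertainty, not a reading from the data.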

Compound 3, minimum cytotoxic concentration: >= 80000 nM
Compound 3: only a limit was reported (the forecaster's own chance of this, stated with the estimate: 80%); middle value at least 1.3-fold (0.12 log units) away from the limit.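

In this assay compound 3 gives >= 80000 nM, a limit of the assay and not a number. For the compounds shown here, compound 1 and compound 2 also stand only as limits, so no step among the three can be read. From the compounds shown here alone, whether the tolerated concentration changes with chain length, and by how much, stays open.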